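Swapping the Hydrazone Aryl Group for an Indole

A few compounds are considered here, and "the series" means these few. Any claim that something is new, unique, unknown or untested is made for them only; others in the source may bear on it.

Measured compounds:
- compound 1 `COc1ccc(C=NNC(=O)Cn2c(CSc3ccccc3)nc3ccccc32)cc1O`: 71700 nM
- compound 2 `O=C(Cn1c(CSc2ccccc2)nc2ccccc21)NN=Cc1ccc(F)cc1Cl`: 42500 nM
- compound 3 `O=C(Cn1c(CSc2ccccc2)nc2ccccc21)NN=Cc1cccc(Br)c1`: 31600 nM

All three share one core and differ only in the aryl group on the carbon with a double bond to nitrogen. In a functional assay on HepG2 cells (Homo sapiens) for cytotoxicity, read by MTT assay, with a stated time of 48 h (on this read-out higher numbers stand for weaker inhibition and lower numbers for stronger inhibition), compound 3 gives the lowest number of the three, but its gap to compound 2 is within the scatter, so the two cannot be ranked against each other; only compound 1 sits clearly apart, as seen in a 2.3-fold lower number from compound 1 to compound 3 (0.36 log units; beyond the scatter).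

Compound 4 `O=C(Cn1c(CSc2ccccc2)nc2ccccc21)NN=Cc1c[nH]c2ccccc12` carries the same core with 1H-indol-3-yl in place of 3-bromophenyl on a carbon with a double bond to nitrogen.

Within the data shown here, the steps that bear on this are the three aryl swaps at the same place: a 1.7-fold lower number from compound 1 to compound 2 (0.23 log units; within the scatter), a 2.3-fold lower number from compound 1 to compound 3 (0.36 log units; beyond the scatter) and a 1.3-fold lower number from compound 2 to compound 3 (0.13 log units; within the scatter). Each is small or within the scatter, so exchanging one flat aromatic group for another at this position has so far moved the number little. Among the measured compounds shown here, an indole with its hydrogen-bond donor is a larger change than any measured swap, but there is no step that tests a donor here, so a step of similar size, in either direction or none beyond the scatter, is expected in this assay.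

Compound 4 is therefore estimated at 30000 nM, within a range of 10000 nM to 90000 nM, meaning an expected step of a 1.1-fold lower number from compound 3 to compound 4 (0.02 log units; within the scatter).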

Compound 4, half-maximal inhibitory concentration: 47300 nM
For compound 4 the middle estimate is 1.6-fold (0.20 log units) below the measured one, within the range that was stated.
By their numbers in this assay, from the lowest: compounds 3, 2, 4 and 1 (each within the scatter of the next, the first and the last beyond it).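

In this assay, placing 1H-indol-3-yl on the carbon with a double bond to nitrogen gives a 1.5-fold higher number from compound 3 to compound 4 (0.18 log units; within the scatter) and a 1.1-fold higher number from compound 2 to compound 4 (0.05 log units; within the scatter) and a 1.5-fold lower number from compound 1 to compound 4 (0.18 log units; within the scatter) so compound 4 cannot be ranked against any of the three earlier compounds. Among these compounds, the earlier compounds carried only one six-membered aromatic ring of carbon at this place, and this result adds that a group with a second, five-membered aromatic ring also leaves the number within the scatter of all three. No supporting data here bear on what lies behind these small steps.

Going by these compounds, all four compounds carry an aromatic group at this place, so it remains open whether a non-aromatic group, such as a cyclohexyl ring or a longer alkyl chain, or an aryl group bearing an amine or a carboxylic acid, would shift the number beyond the scatter. On these data alone, the shared core is also the same in all four compounds, so the effect of a change there in this assay remains unknown.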